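The compounds below may be only part of what the source reports. "The series", "measured", "known", "first", "only" and "open" are said of these compounds alone.

Compound 1 `COc1ccc2nc(C)cc(OCC(=O)Nc3ccccc3)c2c1` and compound 2 `COc1ccc2nc(C)cc(OCC(=O)Nc3ccc(C)cc3)c2c1` share a core, and compound 3 `COc1ccccc1NC(=O)COc1cc(C)nc2ccccc12` carries the same atoms joined differently; the difference between the two cores is not broken down here. Compound 4 `COc1ccccc1NC(=O)COc1cc(C)nc2ccc(C)cc12` is not yet measured. In an ADME assay on HepG2 cells (Homo sapiens) for cytotoxicity, read by trypan blue exclusion, with a stated time of 48 h, in the presence of a further agent that is not named here (a lower number here means that less compound is tolerated, a higher number that more compound is tolerated), compound 1 gives 118000 nM, compound 2 gives 41500 nM and compound 3 gives 8640 nM. From compound 1 to compound 2 the change is methyl in place of hydrogen on an aromatic carbon, and it brought a 2.8-fold lower number from compound 1 to compound 2 (0.45 log units; beyond the scatter). From compound 3 to compound 4 the change is methyl in place of hydrogen on an aromatic carbon. It is the same kind of change, not the same: in compound 2 the methyl sits para to a large group, whereas in compound 4 it sits on a fused or bridged system of two rings, meta to a fused ring and para to a fused ring. Resting on the step from compound 1 to compound 2 in this assay, and allowing for the different place, a somewhat smaller lowering is expected, a 1.9-fold lower number from compound 3 to compound 4 (0.28 log units; within the scatter). Compound 4 is therefore estimated at 4500 nM, within a range from 2000 nM to 12000 nM.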

Compound 4, half-maximal cytotoxic concentration: > 74000 nM
Compound 4 ended at the assay's limit; the forecaster's own chance of this, stated with the estimate: 5%; middle value at least 16-fold (1.21 log units) from the limit.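

In this assay, methyl in place of hydrogen on an aromatic carbon gave an at least 8.5-fold higher number from compound 3 to compound 4 (0.93 log units; beyond the scatter), so this change did not carry over from one core to the other, in either direction or size: the same change on two cores in this assay, a 2.8-fold lower number (0.45 log units; beyond the scatter) from compound 1 to compound 2 and an at least 8.5-fold higher number (0.93 log units; beyond the scatter) from compound 3 to compound 4, at least 24-fold (1.38 log units) apart, beyond the scatter of two such steps. The result for compound 4, > 74000 nM, is a limit of the assay and not a number, so its step has a known minimum but no known size: the limit of > 74000 nM in this assay, at which 1 of the 4 values shown sits. For the compounds shown here, this shows that, in this series, a step seen on one core is a poor guide to the same change on the other, but it does not show why the two steps differ: the methyl sits in a different place in each pair, and each core offers only one pair.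

Going by these compounds, it remains open whether the core or the place of the methyl separates the two steps. Also open, on these data alone, is whether an ethyl group, an amine or a carboxylic acid on the same carbon as the methyl of compound 4 would behave as the methyl does.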